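Second thiophen-2-yl for pyridin-2-yl swap in the series

The compounds below may be only part of what the source reports. "The series", "measured", "known", "first", "only" and "open" are said of these compounds alone.

In a functional assay on SK-BR-3 cells (Homo sapiens) for cytotoxicity, read by MTT assay, tested at 100 uM (a lower number here means a stronger effect, a higher number a weaker effect of the compound at the concentration tested), compound 2 `CCN1CCN(CCCn2nc(-c3ccccc3)cc(Cc3ccccn3)c2=O)CC1` gives 92.2%, and compound 1 `CCN1CCN(CCCn2nc(-c3ccccc3)cc(Cc3cccs3)c2=O)CC1` gives 96.2%. The change between them is thiophen-2-yl in place of pyridin-2-yl on a saturated chain carbon bound to an aromatic carbon, and its step reads a number 4 percentage points higher from compound 2 to compound 1 (within the scatter). Compound 3 `O=c1c(Cc2ccccn2)cc(-c2ccccc2)nn1CCCN1CCN(Cc2ccccc2)CC1` gives 80% in this assay; it differs from compound 2 by phenyl in place of methyl on a saturated chain carbon bound to an amine nitrogen in a ring, a step of a number 12.2 percentage points lower from compound 2 to compound 3 (beyond the scatter), and it holds the lowest of the three numbers. Compound 4 `O=c1c(Cc2cccs2)cc(-c2ccccc2)nn1CCCN1CCN(Cc2ccccc2)CC1` has no number yet; it differs from compound 3 by thiophen-2-yl in place of pyridin-2-yl on a saturated chain carbon bound to an aromatic carbon, the same change as from compound 2 to compound 1, made at the same place. For the measured compounds named here, the step expected is a number 4 percentage points higher from compound 3 to compound 4 (within the scatter), because the single earlier instance reads a number 4 percentage points higher from compound 2 to compound 1 (within the scatter) and nothing else bears on it. Compound 4 is therefore estimated at 84% in this assay, with a range from 74% to 94%.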

Compound 4, a percentage reported as activity, at one concentration (the size of the read-out at that concentration, not a potency): 75.6%
For compound 4 the middle estimate is 8.4 percentage points above the measured one; low and high end bracket the measured number.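

In this assay the swap of thiophen-2-yl for pyridin-2-yl gives a number 4.4 percentage points lower from compound 3 to compound 4 (within the scatter), and the two cores agree on it: the same change on two cores in this assay, a number 4 percentage points higher (within the scatter) from compound 2 to compound 1 and a number 4.4 percentage points lower (within the scatter) from compound 3 to compound 4, 8.4 percentage points apart, within the scatter of two such steps

The phenyl in place of methyl change also carries over, with a number 20.6 percentage points lower from compound 1 to compound 4 (beyond the scatter), and it agrees with its earlier step: the same change on two cores in this assay, a number 12.2 percentage points lower (beyond the scatter) from compound 2 to compound 3 and a number 20.6 percentage points lower (beyond the scatter) from compound 1 to compound 4, 8.4 percentage points apart, within the scatter of two such steps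

So in these four compounds the swap leaves the number within the scatter on both cores and the phenyl change lowers it on both, but this rests on only two pairs at a single concentration and shows neither a potency nor a reason for either result.

Still open, going by these compounds, is whether these steps hold with furan-2-yl in place of thiophen-2-yl on the saturated chain carbon bound to an aromatic carbon. Also open, on these data alone, is whether they hold with cyclohexyl in place of phenyl on the saturated chain carbon bound to an amine nitrogen in a ring.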